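A few compounds are considered here, and "the series" means these few. Any claim that something is new, unique, unknown or untested is made for them only; others in the source may bear on it.

Measured in a physicochemical assay for solubility, at pH 7 (on this read-out higher numbers stand for higher solubility and lower numbers for lower solubility), so far, each reading a limit:
- compound 1 `CC1(C)c2[nH]nc(NC(=O)c3ccc(F)cc3)c2CN1C(=O)C1CCN(C2CC2)CC1` gives > 225000 nM as a limit
- compound 2 `CN1CCC(C(=O)N2Cc3c(NC(=O)c4cc(F)cc(F)c4)n[nH]c3C2(C)C)CC1` gives > 225000 nM as a limit
- compound 3 `CC(C)CC(=O)Nc1n[nH]c2c1CN(C(=O)C1CCN(C3CC3)CC1)C2(C)C` gives > 225000 nM as a limit

Compound 1 thus stands at a limit and not at a number. Compound 4 `CCN1CCC(C(=O)N2Cc3c(NC(=O)c4ccc(F)cc4)n[nH]c3C2(C)C)CC1` carries ethyl in place of cyclopropyl on an amine nitrogen in a ring and is otherwise unchanged. Among the compounds with values here, the one measured step is a step that the two limits leave unreadable from compound 1 to compound 3 for isobutyl in place of 4-fluorophenyl on a carbonyl carbon, a change at another place. The series shows the limit of > 225000 nM in this assay, at which 3 of the 3 values shown sit, and gives no readable step size. In this assay the expected step is a number no higher from compound 1 to compound 4 (the limit leaves the size open) and none beyond the scatter. The estimate for compound 4 is 225000 nM with an expected range from 110000 nM to 450000 nM and a limit as the likely report.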

Compound 4, solubility: > 225000 nM
Compound 4 was reported as a limit; the forecaster's own chance of this, stated with the estimate: 85%; the middle value lies on the limit itself.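

In this assay compound 1 and compound 4 are both limits, so no step can be read between them: the limit of > 225000 nM in this assay, at which 4 of the 4 values shown sit. The compounds shown leave open the actual number for each compound and the size of any step in the series.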